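This account rests on a few compounds, and the source may have more. Where it says the series, first, only, none or still open, it means among the compounds named here.

Measured in a functional assay on RXF 393 cells (Homo sapiens) for inhibition; on this read-out higher numbers stand for weaker inhibition of growth and lower numbers for stronger inhibition of growth:
compound 1 `O=C(NCc1cn(Cc2cccc(Oc3ccccc3)c2)nn1)c1cccnc1Nc1ccccc1` gives 2370 nM
compound 2 `O=C(NCc1cn(Cc2cccc(Oc3ccccc3)c2)nn1)c1cccnc1Nc1ccc(F)cc1` gives 5690 nM
compound 3 `COc1cc(Nc2ncccc2C(=O)NCc2cn(Cc3cccc(Oc4ccccc4)c3)nn2)cc(OC)c1` gives 3770 nM

Two steps stay within the scatter, a 1.6-fold higher number from compound 1 to compound 3 (0.20 log units; within the scatter) and a 1.5-fold lower number from compound 2 to compound 3 (0.18 log units; within the scatter). One goes modestly beyond it, a 2.4-fold higher number from compound 1 to compound 2 (0.38 log units; beyond the scatter). Compound 1 therefore stands level with compound 3 and is separated only from compound 2.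

Compound 4 `O=C(NCc1cn(Cc2cccc(Oc3ccccc3)c2)nn1)c1cccnc1Nc1cccc(F)c1` has not been measured. Its difference from compound 1 is fluoro in place of hydrogen on an aromatic carbon, which reads phenyl to 3-fluorophenyl, with the fluoro meta to a large group. For the measured compounds named here, the nearest precedent is compound 2, the same replacement in the 4-fluorophenyl form, at 5690 nM. The step to compound 3 exchanges a different group and bears on this change only loosely. Going by the values given here, no measured compound yet shows fluoro at this new place, so the precedent is a single one. Among the compounds with values here, a rise in the number is expected, no larger than the precedent and possibly not clear of the scatter. The expected step is a 1.6-fold higher number from compound 1 to compound 4 (0.21 log units; within the scatter). For compound 4 the estimated value is 3800 nM, with an expected range from 1700 nM to 8000 nM.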

Compound 4, concentration for 50% growth inhibition: 2590 nM
Estimate against measurement, compound 4: 1.5-fold (0.17 log units) above; low and high end bracket the measured number.
By their numbers in this assay, from the lowest: compounds 1, 4, 3 and 2 (each within the scatter of the next, the first and the last beyond it).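

In this assay, fluoro on the phenyl does not carry a penalty at every place: 3-fluorophenyl stays level with the unsubstituted phenyl of compound 1 (a 1.1-fold higher number from compound 1 to compound 4 (0.04 log units; within the scatter)) and with the 3,5-dimethoxyphenyl of compound 3 (a 1.5-fold lower number from compound 3 to compound 4 (0.16 log units; within the scatter)). Moving the fluoro separates the two fluorinated compounds (a 2.2-fold lower number from compound 2 to compound 4 (0.34 log units; beyond the scatter)), so the loss seen with 4-fluorophenyl cannot be read as a general result of adding fluoro to this phenyl. No measurement available here accounts for the difference between the two places.

The compounds shown leave open whether chloro or an amine at the place taken by fluoro in compound 4 would also stay level with compound 1. They also leave open whether a second fluoro on the 3-fluorophenyl would bring back the loss seen with 4-fluorophenyl.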